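This account rests on a few compounds, and the source may have more. Where it says the series, first, only, none or still open, it means among the compounds named here.

Measured compounds:
- compound 1 `COc1ccc(OC)c(/C=N/NC(=O)Nc2ccc(Oc3ccnc(-c4nncn4CCN(C)C)c3)c(F)c2)c1` — in a functional assay on A549 cells (Homo sapiens) for cytotoxicity, read by MTT assay, with a stated time of 72 h (a lower number here means a stronger inhibitor, a higher number a weaker inhibitor), compound 1 gives 1950 nM
- compound 2 `CN(C)CCn1cnnc1-c1cc(Oc2ccc(NC(=O)N/N=C/c3ccc(F)cc3Cl)cc2F)ccn1` — in this assay compound 2 gives 1120 nM
- compound 3 `CN(C)CCn1cnnc1-c1cc(Oc2ccc(NC(=O)N/N=C/c3ccccc3O[N+](=O)[O-])cc2F)ccn1` — in this assay compound 3 gives 1200 nM

Compound 1 has the highest of the three numbers, but its separation from the others is small: a 1.7-fold lower number from compound 1 to compound 2 (0.24 log units; within the scatter) and a 1.6-fold lower number from compound 1 to compound 3 (0.21 log units; within the scatter) both fall within the scatter, as does a 1.1-fold higher number from compound 2 to compound 3 (0.03 log units; within the scatter). On these numbers the three compounds are not distinguishable.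

Compound 4 `Cc1cc(/C=N/NC(=O)Nc2ccc(Oc3ccnc(-c4nncn4CCN(C)C)c3)c(F)c2)cc(C)c1O` is not yet measured. Its difference from compound 1 is 4-hydroxy-3,5-dimethylphenyl in place of 2,5-dimethoxyphenyl on a carbon with a double bond to nitrogen.

The two steps that bear on this change are those from compound 1 to compound 2 and from compound 1 to compound 3, since each swaps the same group at the same place, a carbon with a double bond to nitrogen. Neither moved the number beyond the scatter, and the two replacement groups were unlike one another yet gave near-identical readings. Nothing in the series therefore suggests that the 4-hydroxy-3,5-dimethylphenyl group should behave differently, and no step beyond the scatter is expected in this assay.

For compound 4 the expected step is a 1.4-fold lower number from compound 1 to compound 4 (0.14 log units; within the scatter), a small lowering in line with the two measured swaps. Compound 4 is estimated at 1400 nM, with a range from 600 nM to 3300 nM.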

Compound 4, half-maximal inhibitory concentration: 1640 nM
Estimate against measurement, compound 4: 1.2-fold (0.07 log units) below; low and high end bracket the measured number.
By their numbers in this assay, from the lowest: compounds 2, 3, 4 and 1 (each within the scatter of the next).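

In this assay, exchanging 2,5-dimethoxyphenyl, with 0 hydrogen-bond donors, for 4-hydroxy-3,5-dimethylphenyl, with 1 hydrogen-bond donor, gives a 1.2-fold lower number from compound 1 to compound 4 (0.08 log units; within the scatter), so adding this donor on the carbon with a double bond to nitrogen does not take the reading beyond the scatter. Comparison with the other two groups gives the same outcome, with a 1.4-fold higher number from compound 3 to compound 4 (0.14 log units; within the scatter) and a 1.5-fold higher number from compound 2 to compound 4 (0.17 log units; within the scatter), leaving all four substituted phenyl groups at this place unseparated in this cell read-out. No measured evidence is available to account for this lack of separation.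

Going by these compounds, all four compounds carry a substituted phenyl group at this place, so it remains open whether a carboxylic acid, an amine or a longer chain on that phenyl, or a piperidine in its place, would produce a step beyond the scatter. The rest of the structure is common to all four compounds, so these notes also leave open whether changing the dimethylamino group of the shared core would move the reading.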